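From chloro to 1,3-oxazol-2-yl: an exposure estimate

This account rests on a few compounds, and the source may have more. Where it says the series, first, only, none or still open, it means among the compounds named here.

In an in vivo ADME assay on the whole organism (plasma) for pharmacokinetics, with Rattus norvegicus as the target, at a dose of 50 mg/kg by the oral route (on this read-out higher numbers stand for higher exposure at the dose given and lower numbers for lower exposure), compound 1 `Cc1cc(C)c(N(C)C)c(C)c1NC(=O)c1sccc1S(=O)(=O)Nc1onc(C)c1Cl` gives 6620 nM. Compound 2 `Cc1cc(C)c(NC(=O)c2sccc2S(=O)(=O)Nc2onc(C)c2Cl)c(Cl)c1` reaches 103000 nM, the higher of the two numbers, and its gap to compound 1 lies beyond the scatter. Compound 3 `Cc1cc(C)c(NC(=O)c2sccc2S(=O)(=O)Nc2onc(C)c2Cl)c(-c2ncco2)c1` has 1,3-oxazol-2-yl in place of chloro on an aromatic carbon, ortho to a large group (1,3-oxazol-2-yl in place of chloro on an aromatic carbon). Within the data shown here, no measured pair shows a change at this place, so the expectation rests on little. A fall is expected rather than a rise, since compound 2 at 103000 nM holds the highest number seen so far. The estimated change is a moderate fall, a 3.4-fold lower number from compound 2 to compound 3 (0.54 log units; beyond the scatter), though no change beyond the scatter remains possible. For compound 3 the estimate is 30000 nM, with an expected range of 8000 nM to 100000 nM.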

Compound 3, maximal plasma concentration: 134000 nM
For compound 3 the middle estimate is 4.5-fold (0.65 log units) below the measured one; the whole stated range lies below it.
By their numbers in this assay, from the lowest: compound 1; then compounds 2 and 3 (each within the scatter of the next).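

In this assay, among these compounds, putting 1,3-oxazol-2-yl in place of chloro gives a 1.3-fold higher number from compound 2 to compound 3 (0.11 log units; within the scatter), the first measured change at this place. A group of 5 heavy atoms, with a five-membered aromatic ring and 2 hydrogen-bond acceptors, thus enters where a single chlorine left, ortho to a large group, and compound 3 lies within the scatter of compound 2, so in this one pair the place accepts the larger group without a readable loss of exposure. The data shown offer no measured reason why these two numbers lie so close.

Going by these compounds, whether that tolerance extends to other groups at this place, such as an amine, a carboxylic acid or a longer chain, stays open. One pair also cannot show whether the same exchange would give a similar result on a different core.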